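The source may hold more compounds than are shown below. What is called first, only, known or untested is meant among the compounds shown, and "the series" means these compounds.

Working notes on the series

Three compounds share a tricyclic core with a fused sugar-derived ring and differ in the aryl group on the amine nitrogen or in how the core is joined. Compound 1 `O=C1C(Nc2ccc(Br)cc2)=CC(=O)c2c1nc1n2[C@H]2OC[C@@H](O)[C@H]2OC1` carries a 4-bromophenyl group; compound 2 `COc1ccccc1NC1=CC(=O)c2c(nc3n2[C@H]2OC[C@@H](O)[C@H]2OC3)C1=O` carries a 2-methoxyphenyl group on the same core; compound 3 `COc1ccccc1NC1=CC(=O)c2nc3n(c2C1=O)[C@H]1OC[C@@H](O)[C@H]1OC3` is built from the same atoms as compound 2, joined differently, and the difference between the two cores is not broken down here.

In a functional assay on ECa-109 cells for inhibition, with ECa-109 cell line (Homo sapiens) as the target, read by sulforhodamine B assay (a higher number here means a weaker inhibitor, a lower number a stronger inhibitor), compound 1 gives 1980 nM. Compound 2 reaches only the limit of > 4000 nM in this assay. Compound 3 likewise reaches only the limit of > 4000 nM in this assay. The change from compound 2 to compound 1, (4-bromophenyl in place of 2-methoxyphenyl on an amine nitrogen), gave an at least 2.0-fold lower number from compound 2 to compound 1 (0.30 log units; that floor lies within the scatter); this rests on (the limit of > 4000 nM in this assay, at which 2 of the 3 values shown sit), so the true size of that step is not known.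

Compound 4 `O=C1C=C(Nc2ccc(Br)cc2)C(=O)c2c1nc1n2[C@H]2OC[C@@H](O)[C@H]2OC1` is not yet measured. It stands to compound 3 as compound 1 stands to compound 2, with the same change, (4-bromophenyl in place of 2-methoxyphenyl on an amine nitrogen), at the same place. Going by the values given here, the only guide is the step from compound 2 to compound 1, whose size is bounded below by a limit, so the step from compound 3 to compound 4 is expected to be of at least that size, an at least 1.6-fold lower number from compound 3 to compound 4 (0.20 log units; that floor lies within the scatter), with the lower end also resting on a limit. On that basis compound 4 is expected to give about 2500 nM in this assay, estimated between 900 nM and 7000 nM.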

Compound 4, half-maximal inhibitory concentration: 2850 nM
Compound 4: middle estimate off by 1.1-fold (0.06 log units), on the low side, within the range that was stated.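

Carried onto the core of compound 3, 4-bromophenyl in place of 2-methoxyphenyl on the amine nitrogen gives an at least 1.4-fold lower number from compound 3 to compound 4 (0.14 log units; that floor lies within the scatter) in this assay. Both cores therefore yield a step that can be read only as a floor, and each floor lies within the usual scatter, so the change can be said to carry over only in the loose sense that neither core contradicts the other: the same change on two cores in this assay, an at least 2.0-fold lower number (0.30 log units; that floor lies within the scatter) from compound 2 to compound 1 and an at least 1.4-fold lower number (0.14 log units; that floor lies within the scatter) from compound 3 to compound 4; the limit leaves it open whether they differ. Compound 2 and compound 3 each stand at a limit and not at a number, so these data do not show that the change has the same size on both cores, nor do they give its size on either one: the limit of > 4000 nM in this assay, at which 2 of the 4 values shown sit.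

The compounds shown do not separate the effect of adding the bromine from that of removing the methoxy group, or either of these from where the substituent stands on the phenyl ring. Also open, as far as these compounds go, is how an unsubstituted phenyl, a 2-bromophenyl or a 4-methoxyphenyl on the amine nitrogen would read on each core, and whether any of them would bring the compounds now at the limit into the measurable range.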